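Allyl for ethyl on the shared core of compound 1

The compounds below may be only part of what the source reports. "The series", "measured", "known", "first", "only" and "open" are said of these compounds alone.

Within the data shown here, compound 1 `C=C1C(=O)N(c2ccccc2)N(c2ccccc2)C1CC` stands lowest of the three numbers so far: in a functional assay on HL-60 cells (Homo sapiens) for inhibition, read by MTT assay, with a stated time of 48 h (a lower number here means a stronger inhibitor, a higher number a weaker inhibitor), compound 1 gives 8890 nM. Compound 2 `C=C1C(=O)N(c2ccccc2)N(C)C1CC` gives 750000 nM, the step of an 84-fold higher number from compound 1 to compound 2 (1.93 log units; beyond the scatter) being the largest in the set, and compound 3 `C=C1C(=O)N(c2ccccc2)N(C)C1CCCCCCCCC` gives 49900 nM, with a 15-fold lower number from compound 2 to compound 3 (1.18 log units; beyond the scatter).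

Compound 4 `C=CCC1C(=C)C(=O)N(c2ccccc2)N1c1ccccc1` differs from compound 1 by vinyl in place of methyl on a saturated chain carbon bound to a saturated ring carbon; seen one bond further out, the ethyl becomes an allyl. Of the measured steps, only the chain step from compound 2 to compound 3 bears on this, and it points toward lower numbers when the chain on the saturated ring carbon is lengthened, though heptyl for hydrogen is a far larger change than vinyl for methyl. The nitrogen step from compound 1 to compound 2 is unrelated. The expectation is therefore a step in this assay of at most modest size toward a lower number, a 1.5-fold lower number from compound 1 to compound 4 (0.17 log units; within the scatter), possibly within the scatter. Compound 4 is estimated at 6000 nM, expected within 2000 nM to 20000 nM.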

Compound 4, half-maximal inhibitory concentration: 1320 nM
Estimate against measurement, compound 4: 4.5-fold (0.66 log units) above; the whole stated range lies above it.
By their numbers in this assay, from the lowest: compound 4; then compound 1; then compound 3; then compound 2.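

In this assay, vinyl in place of methyl on a saturated chain carbon bound to a saturated ring carbon gives a 6.7-fold lower number from compound 1 to compound 4 (0.83 log units; beyond the scatter) and shows that this position still responds when phenyl sits on the amine nitrogen. The earlier chain step, a 15-fold lower number from compound 2 to compound 3 (1.18 log units; beyond the scatter), came from a heptyl extension with methyl on that nitrogen, whereas ethyl to allyl is a much smaller change that also lowers the number beyond the scatter. No measurement shown accounts for this step.

Still open, as far as these compounds go, is whether the double bond or the added chain length drives the drop, which a propyl group at this place would help separate. Also open, from the compounds shown here alone, is how a longer chain, or an amine at the chain end, would read on the core of compound 1.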